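Phenoxy for phenyl across two cores

A few compounds are considered here, and "the series" means these few. Any claim that something is new, unique, unknown or untested is made for them only; others in the source may bear on it.

Compound 1 `CC(C)(C)OC(=O)N1CCC[C@H]1COCCCCCCCC/C=C/c1ccc(-c2ccccc2)cc1` gives 90000 nM in a functional assay on PANC-1 cells (Homo sapiens) for inhibition, read by XTT assay, with a stated time of 72 h; a lower number here means a stronger inhibitor, a higher number a weaker inhibitor. Compound 2 `CC(C)(C)OC(=O)N1CCC[C@H]1COCCCCCCCC/C=C/c1ccc(Oc2ccccc2)cc1` carries phenoxy in place of phenyl on an aromatic carbon and gives 90000 nM in this assay; the step of no change at the digits printed from compound 1 to compound 2 (within the scatter) is flat. Compound 3 `CC(C)(C)OC(=O)NCC(=O)N1CCC[C@H]1COCCCCCC/C=C/c1ccc(-c2ccccc2)cc1` rests on a different core, and the difference between the two cores is not broken down here; in this assay compound 3 gives 66700 nM, which sits within the scatter of both compound 1 and compound 2. Compound 4 `CC(C)(C)OC(=O)NCC(=O)N1CCC[C@H]1COCCCCCC/C=C/c1ccc(Oc2ccccc2)cc1` is not yet measured and carries phenoxy in place of phenyl on an aromatic carbon, the same change as between compound 1 and compound 2, at the same place. Because the earlier step of no change at the digits printed from compound 1 to compound 2 (within the scatter) was flat, the step of no change at the digits printed from compound 3 to compound 4 (within the scatter) is expected to be flat as well. Compound 4 is therefore estimated at 66700 nM in this assay, with a likely range from 30000 nM to 130000 nM.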

Compound 4, half-maximal inhibitory concentration: 63300 nM
Compound 4: middle estimate off by 1.1-fold (0.02 log units), on the high side; the range from low to high includes it.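

In this assay phenoxy in place of phenyl on the second core gives a 1.1-fold lower number from compound 3 to compound 4 (0.02 log units; within the scatter), and the step reads the same on both cores: the same change on two cores in this assay, no change at the digits printed (within the scatter) from compound 1 to compound 2 and a 1.1-fold lower number (0.02 log units; within the scatter) from compound 3 to compound 4, 1.1-fold (0.02 log units) apart, within the scatter of two such steps. On these two cores the change therefore carries over as a flat step, so phenyl and phenoxy are interchangeable at this place in this assay. This does not show that the step stays flat on any other core, and it does not break down the difference between the two cores.

Still open, going by these compounds, is how a different group at this place would read, such as an amine or a carboxylic acid on the outer ring. Also open, on these data alone, is how a longer chain would read with either group.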